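Anilide series: cytotoxicity notes ahead of compound 3

The source may report more compounds than this note shows. Statements on the series, on what has been measured and on what is new or still open speak of the compounds shown alone.

Working notes on a small anilide series. Compound 1 `O=C(Nc1ccc(Sc2nc3ccccc3s2)cc1)c1cccc(Br)c1` was run in an ADME assay on HEK293 cells (Homo sapiens) for cytotoxicity, read by reporter gene assay and resazurin assay, with a stated time of 48 h; on this read-out higher numbers stand for lower toxicity in this test and lower numbers for higher toxicity in this test; in that test compound 1 gives 74000 nM. Compound 2 `O=C(Nc1ccc(Sc2nc3ccccc3s2)c(Cl)c1)c1cccc(Br)c1O` gives 64000 nM in this assay. Compound 2 holds the lowest of the two numbers recorded so far; its nearest neighbour is compound 1, whose number lies within the usual scatter of it, so the two values cannot be told apart. Compound 3 `COc1ccccc1C(=O)Nc1ccc(Sc2nc3ccccc3s2)c(Cl)c1` has not been measured in this assay. Compound 3 differs from compound 2 in one place: 2-methoxyphenyl in place of 3-bromo-2-hydroxyphenyl on a carbonyl carbon. Within the data shown here, no step between two measured compounds is available, so nothing in the numbers so far shows how a change at the carbonyl carbon moves the half-maximal cytotoxic concentration. The expectation is that the step of a 1.1-fold higher number from compound 2 to compound 3 (0.04 log units; within the scatter) stays within the scatter, with no clear direction. For compound 3 the estimated value in this assay is 70000 nM, with a range from 25000 nM to 200000 nM.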

Compound 3, half-maximal cytotoxic concentration: > 100000 nM
Compound 3: a limit, no number (the forecaster's own chance of this, stated with the estimate: 25%); middle value at least 1.4-fold (0.15 log units) from the limit.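

Among these compounds, this is the first reading of a change at the carbonyl carbon: 2-methoxyphenyl in place of 3-bromo-2-hydroxyphenyl gives an at least 1.5-fold higher number from compound 2 to compound 3 (0.19 log units; that floor lies within the scatter) in this assay. The change removes the bromine and the hydrogen-bond donor together, and the number does not fall, so this position accepts the swap with no sign of higher toxicity in this test. Only a floor can be read for the step, because the value of compound 3 is a limit: the limit of > 100000 nM in this assay, at which 1 of the 3 values shown sits.

The compounds shown leave open whether the bromine, the hydroxyl or the methoxy accounts for any part of the step, since the swap changes them together. Also open, as far as these compounds go, is what an amine or a carboxylic acid on the phenyl ring at this carbonyl carbon would give on the shared core.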